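Cytotoxicity limits across three measured analogues

This account rests on a few compounds, and the source may have more. Where it says the series, first, only, none or still open, it means among the compounds named here.

Measured so far:
compound 1 `Clc1ccc2c(NCCn3cnc4c(N5CCCC5)nc(Cl)nc43)ccnc2c1` — > 11100 nM
compound 2 `Clc1ccc2c(NCCn3cnc4c(N5CCCCC5)nc(Cl)nc43)ccnc2c1` — > 10700 nM
compound 3 `Clc1ccc2c(NCCCn3cnc4c(N5CCCC5)nc(Cl)nc43)ccnc2c1` — > 10700 nM

In an ADME assay on Vero cells (Chlorocebus sabaeus) for cytotoxicity, read by neutral red uptake, with a stated time of 48 h (a lower number here means a stronger inhibitor, a higher number a weaker inhibitor), compound 1 gives > 11100 nM, which is a limit of the assay and not a number. Compound 2 gives > 10700 nM in this assay, again only a limit. Compound 3 gives > 10700 nM in this assay, also a limit. Compound 2 differs from compound 1 by piperidin-1-yl in place of pyrrolidin-1-yl on an aromatic carbon; the step is a step that the two limits leave unreadable from compound 1 to compound 2, which cannot be read because the limit of > 10700 nM in this assay, at which 2 of the 3 values shown sit, and the limit of > 11100 nM in this assay, at which 1 of the 3 values shown sits, bound both values. The difference between the core of compound 1 and the core of compound 3 is not broken down here.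

Compound 4 `Clc1ccc2c(NCCCn3cnc4c(N5CCCCC5)nc(Cl)nc43)ccnc2c1` has not yet been measured in this assay. It differs from compound 3 by piperidin-1-yl in place of pyrrolidin-1-yl on an aromatic carbon, the same change as that from compound 1 to compound 2, made at a place described in identical words. Since every measured value sits at a limit, the step that the limit leaves unreadable from compound 3 to compound 4 is expected to be unreadable in the same way, and compound 4 is estimated at 15000 nM, most likely reported only as a limit.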

Compound 4, half-maximal inhibitory concentration: > 10400 nM
Compound 4 ended at the assay's limit; the forecaster's own chance of this, stated with the estimate: 85%; the middle value lies beyond the limit too.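

Going by these compounds alone, compound 3 and compound 4 both stand at limits in this assay, not at numbers, and no step between them can be read. The compounds shown leave open what half-maximal inhibitory concentration any of the four actually has, and so whether piperidin-1-yl in place of pyrrolidin-1-yl changes it at all.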